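The compounds below may be only part of what the source reports. "The series", "measured", "known", "first", "only" and "open" are said of these compounds alone.

Values in a functional assay on KB cells (Homo sapiens) for inhibition (on this read-out higher numbers stand for weaker inhibition and lower numbers for stronger inhibition), both of them limits:
- Compound 1 `COCCOCn1c(Br)c(C#N)c2c(N)ncnc21`: > 100000 nM
- Compound 2 `COCCOCn1c(N(C)C)c(C#N)c2c(N)ncnc21`: > 100000 nM

In this assay, compound 2 stands only at a limit, > 100000 nM. The evidence so far is the limit of > 100000 nM in this assay, at which 2 of the 2 values shown sit. Compound 3 `COCCOCn1c(N)c(C#N)c2c(N)ncnc21` carries amino in place of dimethylamino on an aromatic carbon. Within the data shown here, the only measured step, a step that the two limits leave unreadable from compound 1 to compound 2, concerns this same carbon but offers no size to carry over. No step beyond the scatter is therefore expected in this assay, in either direction. The expected step is a number no higher from compound 2 to compound 3 (the limit leaves the size open). For compound 3 the estimate is 100000 nM, with an expected range from 40000 nM to 200000 nM.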

Compound 3, half-maximal inhibitory concentration: 210000 nM
For compound 3 the middle estimate is 2.1-fold (0.32 log units) below the measured one; measured number outside the range, above it.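

In this assay compound 1 and compound 2 stand only at limits, so neither step to compound 3 can be read: the limit of > 100000 nM in this assay, at which 2 of the 3 values shown sit. The compounds shown leave open how large a change the exchanges among bromo, dimethylamino and amino bring on this aromatic carbon.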